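Nitro for bromo in two bis-indolylmethane cores

The source may hold more compounds than are shown below. What is called first, only, known or untested is meant among the compounds shown, and "the series" means these compounds.

Compound 1 `Brc1ccc(C(c2c[nH]c3ccc(Br)cc23)c2c[nH]c3ccc(Br)cc23)cc1` is the bromo parent of the first core. In a functional assay on A549 cells (Homo sapiens) for inhibition, read by MTT assay, with a stated time of 48 h (on this read-out lower numbers stand for stronger inhibition and higher numbers for weaker inhibition), compound 1 gives 5600 nM. Among the measured compounds shown here, compound 2 `O=[N+]([O-])c1ccc(C(c2c[nH]c3ccc(Br)cc23)c2c[nH]c3ccc(Br)cc23)cc1` carries the single change (nitro in place of bromo on an aromatic carbon), and in this assay compound 2 gives 5500 nM. The step of a 1.0-fold lower number from compound 1 to compound 2 (0.01 log units; within the scatter) shows that, on this core, swapping bromo for nitro leaves the read-out where it was.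

Compound 3 `N#Cc1ccc2[nH]cc(C(c3ccc(Br)cc3)c3c[nH]c4ccc(C#N)cc34)c2c1` belongs to a second core; how the two cores differ is not broken down here. In this assay, for the measured compounds named here, compound 3 returns only a limit, > 100000 nM, and the limit of > 100000 nM in this assay, at which 1 of the 3 values shown sits, marks that it is the one value of the three sitting at that limit.

Compound 4 `N#Cc1ccc2[nH]cc(C(c3ccc([N+](=O)[O-])cc3)c3c[nH]c4ccc(C#N)cc34)c2c1` is not yet measured. It differs from compound 3 by nitro in place of bromo on an aromatic carbon, the same change that separates compound 1 from compound 2, at the same place, para to a large group on the six-membered carbon ring. Going by the values given here, the only measured instance of this change, the step of a 1.0-fold lower number from compound 1 to compound 2 (0.01 log units; within the scatter), lies within the scatter, so the same change on the second core is expected to do little. Since compound 3 gives only a limit, compound 4 is expected to sit at or near that limit as well, with the expected step of a number no higher from compound 3 to compound 4 (the limit leaves the size open) taken as essentially flat. The estimate for compound 4 in this assay is 100000 nM, within a range from 30000 nM to 500000 nM, and a limit rather than a number is the more likely report.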

Compound 4, half-maximal inhibitory concentration: > 100000 nM
Compound 4: only a limit was reported; the forecaster's own chance of this, stated with the estimate: 75%; the middle value sits exactly at the limit.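

In this assay compound 4 gives only a limit, > 100000 nM. Compound 3 also gives only a limit, > 100000 nM. With a limit on each side, no step from compound 3 to compound 4 can be read: the limit of > 100000 nM in this assay, at which 2 of the 4 values shown sit.

The compounds shown leave open whether nitro in place of bromo changes the read-out at all on the core shared by compound 3 and compound 4.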